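Adding a methyl to the limit-bound compound 2

The source may report more compounds than this note shows. Statements on the series, on what has been measured and on what is new or still open speak of the compounds shown alone.

Measured in a functional assay on COR-L23 cells (Homo sapiens) for antiproliferative activity, read by CellTiter-Glo, with a stated time of 4 days; on this read-out higher numbers stand for weaker inhibition and lower numbers for stronger inhibition:
- compound 1 `CC(=O)NCc1ncc2cc(COc3ccc(C(=O)NCc4cccnc4)cc3)n(CCC3CCCCC3)c2n1`: 77 nM
- compound 2 `CCC(=O)NCc1ccc(NC(=O)[C@H]2C[C@@H]2c2cccnc2)cc1`: > 2500 nM

Compound 1 gives a true number in this assay. Compound 2 stands at the limit of > 2500 nM in this assay, at which 1 of the 2 values shown sits. From the compounds shown here alone, its entry is a limit and not a number, so its actual position is unknown.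

The next compound is compound 3 `CCC(=O)N[C@@H](C)c1ccc(NC(=O)[C@H]2C[C@@H]2c2cccnc2)cc1`. It differs from compound 2 by one change: methyl in place of hydrogen on a saturated chain carbon bound to an amide-type nitrogen and an aromatic carbon. In words, this is methyl in place of hydrogen on a saturated chain carbon bound to an amide-type nitrogen and an aromatic carbon.

Within the data shown here, no pair of measured compounds differs in one place, so no measured step shows what this change does in this assay. The expectation is therefore loose: a modest move toward stronger inhibition, with a second limit reading quite possible. The expected change is an at least 2.0-fold lower number from compound 2 to compound 3 (0.31 log units; beyond the scatter). For compound 3 the estimated value is 1200 nM. The expected range for compound 3 runs from 100 nM to 5000 nM.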

Compound 3, half-maximal inhibitory concentration: 22 nM
The estimate for compound 3 lay 55-fold (1.74 log units) above the measured number; measured number outside the range, below it.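

In this assay, methyl in place of hydrogen on a saturated chain carbon bound to an amide-type nitrogen and an aromatic carbon gives an at least 110-fold lower number from compound 2 to compound 3 (2.05 log units; beyond the scatter), the first sign that this carbon strongly affects antiproliferative activity in the series. Compound 2 gives only a limit, so this step is a floor and its full size remains unknown: the limit of > 2500 nM in this assay, at which 1 of the 3 values shown sits.

With compound 3 at 22 nM, a change of one carbon, with no hydrogen-bond donor or acceptor and no net charge added, is enough to give a true number in this assay.

Whether the gain is specific to methyl remains open, since the compounds shown do not tell how an ethyl or a hydroxymethyl on this carbon would read, or how the opposite configuration at this carbon would compare. Also open, from the compounds shown here alone, is whether the change carries over to compound 1, which has a saturated chain carbon bound to an amide-type nitrogen and an aromatic carbon but a different core, so the size of the step may hold only for the core of compound 2.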